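Adding a methoxy group to compound 1

This account rests on a few compounds, and the source may have more. Where it says the series, first, only, none or still open, it means among the compounds named here.

- Compound 1 `CCCOc1ccccc1-c1ncc(C(=O)O)c(=O)[nH]1`: 0.9 mg/kg
- Compound 2 `O=C(O)c1cnc(-c2ccccc2OCC2CC2)[nH]c1=O`: 0.1 mg/kg
- Compound 3 `CSc1ccccc1-c1ncc(C(=O)O)c(=O)[nH]1`: > 20 mg/kg, a limit

In a functional assay on the whole organism (strain Sprague-Dawley) for inhibition, with Rattus norvegicus as the target, with a stated time of 10 min (a lower number here means that less compound is needed, a higher number that more compound is needed for the effect), compound 1 gives 0.9 mg/kg, the higher of the two actual numbers. For compound 3, the reported value is only a limit.

Compound 4 `CCCOc1ccc(OC)cc1-c1ncc(C(=O)O)c(=O)[nH]1` keeps the propoxy group of compound 1 and carries a new group: methoxy in place of hydrogen on an aromatic carbon. Among the measured compounds shown here, no measured step adds a group at this place. The nearest guides change the propoxy group instead: a 9.0-fold lower number from compound 1 to compound 2 (0.95 log units; beyond the scatter) and an at least 22-fold higher number from compound 1 to compound 3 (1.34 log units; beyond the scatter). Both are clear steps, but they point in opposite directions, so they give no direction here. No step beyond the scatter is expected, and the expected step is a 1.3-fold higher number from compound 1 to compound 4 (0.12 log units; within the scatter). Compound 4 is estimated at 1.2 mg/kg, with an expected range from 0.3 mg/kg to 6 mg/kg.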

Compound 4, dose for 50% inhibition: 0.3 mg/kg
Compound 4: the middle estimate sits 4.0-fold (0.60 log units) above what was measured; the range from low to high includes it.
By their numbers in this assay, from the lowest: compound 2; then compound 4; then compound 1. At a limit, above all of these: compound 3.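

Adding methoxy on the aromatic carbon para to a propoxy group gives a 3.0-fold lower number from compound 1 to compound 4 (0.48 log units; beyond the scatter) in this assay, so this place on the ring takes a new group and the number falls. Among the compounds shown here, the earlier steps changed only the propoxy group, so this is the first sign that a change elsewhere on that ring also counts. Nothing shown here gives a reason for this step.

Going by these compounds, whether a fluorine, a chlorine or an amine at this place would act like methoxy stays open. So does whether methoxy would lower the number again on compound 2, with its cyclopropylmethoxy group.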